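The compounds below may be only part of what the source reports. "The series", "measured", "known", "first", "only" and "open" are said of these compounds alone.

Measured compounds:
compound 1 `Cc1c(/C=N/N2CCN(C)CC2)c2ccccc2n1S(=O)(=O)c1ccc2ccccc2c1`: 2040 nM
compound 2 `CN1CCN(/N=C/c2c(-c3ccccc3)n(S(=O)(=O)c3ccccc3)c3ccccc23)CC1`: 1800 nM
compound 3 `CN1CCN(/N=C/c2c(-c3ccccc3)n(S(=O)(=O)c3ccc(F)cc3)c3ccccc23)CC1`: 2900 nM

In a functional assay on HEK293 cells for antagonist activity at 5-hydroxytryptamine receptor 6 (Homo sapiens), read by cAMP accumulation, with stated times of 10 min and 1 h (a higher number here means a weaker inhibitor, a lower number a stronger inhibitor), the three numbers lie within the usual scatter of one another, so compound 2 cannot be set apart from compound 1 or compound 3 on these data; compound 2 and compound 1 in particular are all but indistinguishable, and compound 3 is only a little way off.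

Compound 4 `CN1CCN(/N=C/c2c(-c3ccccc3)n(S(=O)(=O)c3cccc4c3OCCO4)c3ccccc23)CC1` differs from compound 2 at the aryl group on the sulfonyl sulfur: 2,3-dihydro-1,4-benzodioxin-5-yl in place of phenyl on a sulfonyl sulfur. For the measured compounds named here, the only measured step that bears on this position is the one on the same aryl group, from compound 2 to compound 3, which gave a 1.6-fold higher number from compound 2 to compound 3 (0.21 log units; within the scatter). That step is small and is a much lighter change than the fused dioxin ring entering here, so it sets only a weak precedent. With nothing else in the series touching this aryl group, the expectation for compound 4 is a number near that of compound 2, with no step beyond the scatter in either direction, though the wider range allows for some drift.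

The step from compound 2 to compound 4 is therefore estimated as a 1.2-fold higher number from compound 2 to compound 4 (0.09 log units; within the scatter). Compound 4 is expected at 2200 nM, within a range from 900 nM to 5500 nM.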

Compound 4, half-maximal inhibitory concentration: 3800 nM
For compound 4 the middle estimate is 1.7-fold (0.24 log units) below the measured one, within the range that was stated.
By their numbers in this assay, from the lowest: compounds 2, 1, 3 and 4 (each within the scatter of the next, the first and the last beyond it).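

In this assay, 2,3-dihydro-1,4-benzodioxin-5-yl in place of phenyl on a sulfonyl sulfur gives a 2.1-fold higher number from compound 2 to compound 4 (0.32 log units; beyond the scatter), a modest step but the first at this position to pass the scatter, whereas the fluoro change gave only a 1.6-fold higher number from compound 2 to compound 3 (0.21 log units; within the scatter). Set against 4-fluorophenyl, the same group gives a 1.3-fold higher number from compound 3 to compound 4 (0.12 log units; within the scatter), so compound 4 cannot be separated from compound 3, and the loss in inhibition is visible only against the unsubstituted phenyl of compound 2. Nothing available accounts for the step from phenyl to the fused group.

Still open, on these data alone, is whether the step follows the two oxygen atoms of the fused ring or the larger group as a whole, which a methoxy group or an ethoxy group on the phenyl ring at the same sulfonyl sulfur could help to separate. Also open, as far as these compounds go, is whether any aryl group at this place, for example one carrying an amine or a carboxylic acid, moves the number below that of compound 2 by more than the scatter.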